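Sulfonamide series: the step from compound 2 to compound 4

The compounds below may be only part of what the source reports. "The series", "measured", "known", "first", "only" and "open" are said of these compounds alone.

Measured so far:
compound 1 `O=S(=O)(Nc1ccc(-c2nc3ccccc3o2)cc1)c1ccc(Cl)c(C(F)(F)F)c1`: 12000 nM
compound 2 `O=S(=O)(Nc1ccc(-c2nc3ccccc3o2)cc1)c1ccc(Cl)s1`: 31000 nM
compound 3 `O=S(=O)(Nc1ccc2oc(-c3ccccc3)nc2c1)c1cccs1`: 90000 nM

All three were tested in an assay on cells for inhibition of HSP60/HSP10 (Homo sapiens), with a stated time of 60 min; a lower number here means a stronger inhibitor, a higher number a weaker inhibitor. Compound 2 stands second highest of the three numbers; compound 1 is nearest with a lower number, compound 3 furthest with a higher number, and both gaps lie beyond the scatter. Compound 4 `COc1ccc(S(=O)(=O)Nc2ccc(-c3nc4ccccc4o3)cc2)cc1` is not yet measured. It differs from compound 2 in one place: 4-methoxyphenyl in place of 5-chlorothiophen-2-yl on a sulfonyl sulfur. For the measured compounds named here, no pair of measured compounds shows this exact change, so the step size rests on the whole set. Among the measured compounds, only compound 1 also carries a six-membered aromatic ring of carbon only on the sulfonyl sulfur; in this assay compound 1 gives 12000 nM, below compound 2. The expected step is therefore a 2.1-fold lower number from compound 2 to compound 4 (0.32 log units; beyond the scatter). For compound 4 the estimate in this assay is 15000 nM, expected between 4000 nM and 60000 nM.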

Compound 4, half-maximal inhibitory concentration: > 100000 nM
Compound 4 was reported as a limit; the forecaster's own chance of this, stated with the estimate: 10%; middle value at least 6.6-fold (0.82 log units) from the limit.
By their numbers in this assay, from the lowest: compound 1; then compound 2; then compound 3. At a limit, above all of these: compound 4.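

In this assay compound 4 gives > 100000 nM, which is a limit of the assay. Placing 4-methoxyphenyl in place of 5-chlorothiophen-2-yl on the sulfonyl sulfur gives an at least 3.2-fold higher number from compound 2 to compound 4 (0.50 log units; beyond the scatter), so this position does not tolerate every aromatic group. A six-membered aromatic ring of carbon only is thus not enough by itself: compound 1, which also carries one there, gives 12000 nM.

On these data alone, how far compound 4 lies past the limit stays open: the limit of > 100000 nM in this assay, at which 1 of the 4 values shown sits. Also open is how an amine or a carboxylic acid on the ring at the sulfonyl sulfur would read in this assay.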